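Swapping the Outer Five-Membered Ring: Pyrazole to Tetrazole

The compounds below may be only part of what the source reports. "The series", "measured", "known", "first", "only" and "open" are said of these compounds alone.

Compound 3 `CCC(C)(C)Cc1c[nH]c(CCc2ccc(-n3cccn3)cc2)n1` carries a 1H-pyrazol-1-yl group on its outer benzene ring, and in a functional assay on HEK293 cells for agonist activity at Bombesin receptor subtype-3 (Homo sapiens), read by luminescence and calcium flux, with a stated time of 10 min (on this read-out lower numbers stand for an effect already at smaller amounts and higher numbers for an effect only at larger amounts of compound), compound 3 gives 106 nM. Its two measured neighbours differ only in that outer group. Compound 1 `CCC(C)(C)Cc1c[nH]c(CCc2ccc(-c3cccc(C)n3)cc2)n1` bears a 6-methylpyridin-2-yl group there and in this assay compound 1 gives 102 nM, while compound 2 `CCC(C)(C)Cc1c[nH]c(CCc2ccc(-c3ccncc3)cc2)n1` bears a pyridin-4-yl group and in this assay compound 2 gives 95 nM. All three numbers sit within the scatter of one another: the step was a 1.1-fold lower number from compound 1 to compound 2 (0.03 log units; within the scatter), then a 1.0-fold higher number from compound 1 to compound 3 (0.02 log units; within the scatter), and a 1.1-fold higher number from compound 2 to compound 3 (0.05 log units; within the scatter). Compound 3 therefore stands level with the other two rather than apart from them.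

Compound 4 `CCC(C)(C)Cc1c[nH]c(CCc2ccc(-n3ncnn3)cc2)n1` takes the next step in the same place: 2H-tetrazol-2-yl in place of 1H-pyrazol-1-yl on an aromatic carbon. The group that leaves and the group that enters are both five-membered aromatic rings on the same aromatic carbon. The three measured steps bear directly on this question, since each swapped one outer ring for another and none moved the number beyond the scatter. The expected step is therefore a 1.1-fold higher number from compound 3 to compound 4 (0.05 log units; within the scatter), meaning no change beyond the scatter is anticipated. Compound 4 is estimated at 120 nM, with an expected range from 50 nM to 300 nM.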

Compound 4, half-maximal effective concentration: 89 nM
Compound 4: middle estimate off by 1.3-fold (0.13 log units), on the high side; the range from low to high includes it.
By their numbers in this assay, from the lowest: compounds 4, 2, 1 and 3 (each within the scatter of the next).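

Replacing two ring carbons of the pyrazole with nitrogen, so that the outer ring goes from 3 carbon and 2 nitrogen atoms to 1 carbon and 4 nitrogen atoms and from 2 hydrogen-bond acceptors to 4, does not shift the result in this assay: the swap gives a 1.2-fold lower number from compound 3 to compound 4 (0.08 log units; within the scatter). The tetrazole also stands level with the two six-membered outer rings, with a 1.1-fold lower number from compound 2 to compound 4 (0.03 log units; within the scatter) and a 1.1-fold lower number from compound 1 to compound 4 (0.06 log units; within the scatter). This place on the outer benzene ring, para to a large group, therefore accepts a five-membered aromatic ring with 4 hetero atoms as readily as the rings seen earlier, and none of the four compounds goes against that. Nothing given here explains why the number stays so flat.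

Going by these compounds, all four outer groups are aromatic rings, so it remains open whether a group of another kind at this place, such as an amine, a carboxylic acid or a longer alkyl chain, would keep the number level. The compounds shown also share the same core and side chain, so they say nothing about how a change elsewhere in the molecule would act.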